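Aryl ether to methyl ether on the pyridine oxygen

The source may report more compounds than this note shows. Statements on the series, on what has been measured and on what is new or still open speak of the compounds shown alone.

Measured so far:
compound 1 `CN1CC2C=C(c3cncc(Cl)c3)CC(C2)C1`: 1830 nM
compound 2 `Clc1ccccc1Oc1cncc(C2=CC3CNCC(C2)C3)c1`: 26 nM

In an in vitro assay on SH-SY5Y cells for displacement of a labelled ligand from Neuronal acetylcholine receptor; alpha3/beta4 (Homo sapiens) (on this read-out higher numbers stand for weaker inhibition and lower numbers for stronger inhibition), compound 1 gives 1830 nM and compound 2 gives 26 nM. Compound 2 therefore holds the lower of the two numbers, and the gap to compound 1 lies beyond the scatter; the two differ in more than one place, so their values are only compared, not attributed.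

Compound 3 `COc1cncc(C2=CC3CNCC(C2)C3)c1` is the next compound, not yet measured. Its relation to compound 2 is: methyl in place of 2-chlorophenyl on an oxygen on an aromatic ring. The core and the secondary amine of compound 2 are retained.

Going by the values given here, no single-change step between measured compounds is available to calibrate this change. The expectation is a weakening in this assay beyond the scatter, as the expected step of a 5.8-fold higher number from compound 2 to compound 3 (0.76 log units; beyond the scatter). Compound 3 is estimated at 150 nM, within 40 nM to 600 nM.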

Compound 3, inhibition constant: 14.3 nM
The estimate for compound 3 lay 10-fold (1.02 log units) above the measured number, outside the stated range (below it).
By their numbers in this assay, from the lowest: compounds 3 and 2 (each within the scatter of the next); then compound 1.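

In this assay, methyl in place of 2-chlorophenyl on an oxygen on an aromatic ring gives a 1.8-fold lower number from compound 2 to compound 3 (0.26 log units; within the scatter), so the two compounds cannot be told apart on this read-out. At this position, then, the 2-chlorophenyl group with its 7 heavy atoms and its aromatic ring is not required for a value in this range: a single methyl carbon serves as well in this pair. Nothing on hand bears on why the two compounds read alike.

Open, from the compounds shown here alone, is how much else this position tolerates, for instance an ethyl group or a longer chain on the oxygen, an unsubstituted phenyl, or a free hydroxyl. Also open, going by these compounds, is whether the oxygen itself matters, which an amine at that place would test, and how a methyl on the core nitrogen acts alone.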